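Compound 3 in the rat cell assay: a larger amine ring

The source may hold more compounds than are shown below. What is called first, only, known or untested is meant among the compounds shown, and "the series" means these compounds.

Compound 1 `CN(C)C12C/C(=N\O)C(C(c3ccccc3)C1)C(c1ccccc1)C2`: 150000 nM
Compound 2 `O/N=C1\CC2(N3CCCC3)CC(c3ccccc3)C1C(c1ccccc1)C2`: 13500 nM

In an ADME assay on L6 cells (Rattus norvegicus) for cytotoxicity (on this read-out lower numbers stand for stronger inhibition and higher numbers for weaker inhibition), compound 2 gives 13500 nM, the lower of the two measured numbers. The next change leads to compound 3 `O/N=C1\CC2(N3CCCCC3)CC(c3ccccc3)C1C(c1ccccc1)C2`, with piperidin-1-yl in place of pyrrolidin-1-yl on a saturated ring carbon. Going by the values given here, one measured step bears on this, an 11-fold lower number from compound 1 to compound 2 (1.05 log units; beyond the scatter), where pyrrolidin-1-yl replaced dimethylamino on that same carbon. Among the compounds with values here, this large step lies beyond the scatter, but it is the only such step, and no measured pair compares two ring amines. The swap here is of one ring amine for another, so a much smaller move is expected, perhaps slightly downward and not clearly beyond the scatter. The expected step is a 1.2-fold lower number from compound 2 to compound 3 (0.09 log units; within the scatter). Compound 3 is estimated at 11000 nM, with an expected range of 4500 nM to 30000 nM.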

Compound 3, half-maximal inhibitory concentration: 24200 nM
Compound 3: the middle estimate sits 2.2-fold (0.34 log units) below what was measured; the range from low to high includes it.
By their numbers in this assay, from the lowest: compounds 2 and 3 (each within the scatter of the next); then compound 1.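

In this assay, the two ring amines on this saturated ring carbon can now be compared directly: piperidin-1-yl in place of pyrrolidin-1-yl gives a 1.8-fold higher number from compound 2 to compound 3 (0.25 log units; within the scatter), so this assay does not separate the five-membered ring from the six-membered one. Dimethylamino remains the outlier, since the swap to piperidin-1-yl gives a 6.2-fold lower number from compound 1 to compound 3 (0.79 log units; beyond the scatter), a step in the same direction as an 11-fold lower number from compound 1 to compound 2 (1.05 log units; beyond the scatter), and both ring amines thus stand apart from dimethylamino at this position. Nothing measured here explains this separation.

The compounds shown leave open whether it is the closed ring itself that matters or only the number of carbons on the nitrogen. A diethylamino group, or a morpholin-4-yl ring on the same carbon, would help to settle that.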